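This account rests on a few compounds, and the source may have more. Where it says the series, first, only, none or still open, it means among the compounds named here.

Measured so far:
compound 1 `CNc1nncc2cncn12` — > 48000 nM
compound 2 `CNc1nncc2c(C)ncn12` — > 48000 nM

Compound 1 has the structure `CNc1nncc2cncn12`. In a functional assay for inhibition, with Homo sapiens as the target (a higher number here means a weaker inhibitor, a lower number a stronger inhibitor), compound 1 reaches only a limit of the assay, > 48000 nM, and no number. Compound 2, `CNc1nncc2c(C)ncn12`, differs from it by a methyl in place of hydrogen on an aromatic carbon. In this assay compound 2 also reaches only a limit, > 48000 nM. For the measured compounds named here, the single measured step, a step that the two limits leave unreadable from compound 1 to compound 2, cannot be read because of the limit of > 48000 nM in this assay, at which 2 of the 2 values shown sit. So compound 2 stands at a limit, with nothing above or below it that can be ordered.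

Compound 3, `Cc1ncn2c(O)nncc12`, follows from compound 2 by hydroxy in place of methylamino on an aromatic carbon. Going by the values given here, no measured step involves this change, and the one step that exists gives no readable size. What is known is that both measured compounds sit at the same limit. On that basis compound 3 is expected to stay near that limit, so the expected step of a number no higher from compound 2 to compound 3 (the limit leaves the size open) is none beyond the scatter. Compound 3 is estimated at 48000 nM, in the range 15000 nM to 200000 nM.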

Compound 3, half-maximal inhibitory concentration: > 48000 nM
Compound 3 ended at the assay's limit (the forecaster's own chance of this, stated with the estimate: 85%); the middle value sits exactly at the limit.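

Compound 3, like compound 2, reaches only a limit in this assay and no number, so no new step can be read between them, because every value shown sits at the same limit: the limit of > 48000 nM in this assay, at which 3 of the 3 values shown sit. The compounds shown leave open how strongly any of them inhibits, and whether methylamino or hydroxy on the shared core makes any difference in this assay.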